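The compounds below may be only part of what the source reports. "The series", "measured", "known", "first", "only" and "open" are said of these compounds alone.

Measured so far in a functional assay on a cell-free system (Platelet, plasma, Homo sapiens) for inhibition; a lower number here means a stronger inhibitor, a higher number a weaker inhibitor:
compound 1 `O=C(O)CCCN1Cc2ccc(NC(=O)CC3CCNCC3)cc2C1=O` — 1800 nM
compound 2 `O=C(O)CN1Cc2ccc(NC(=O)c3ccc(N4CCNCC4)cc3)cc2C1=O` — 3300 nM
compound 3 `CC(CC(=O)O)N1Cc2ccc(NC(=O)c3ccc4c(c3)CNCC4)cc2C1=O` — 86 nM

Compound 3 stands lowest of the three numbers in this assay; both other compounds lie beyond the scatter from it, compound 1 nearest and compound 2 furthest.

Compound 4 `O=C(O)CCN1Cc2ccc(NC(=O)c3ccc4c(c3)CNCC4)cc2C1=O` is not yet measured. It differs from compound 3 in one place: hydrogen in place of methyl on a saturated chain carbon bound to an amide-type nitrogen in a ring and a saturated chain carbon. Within the data shown here, no step between measured compounds isolates this change, so its size cannot be read from the data. Removal of a methyl at a saturated chain carbon bound to the amide-type nitrogen in the ring is expected to give a small step, a 1.7-fold higher number from compound 3 to compound 4 (0.24 log units; within the scatter), toward a weaker inhibitor or none beyond the scatter. Compound 4 is thus expected at 150 nM, with a range of 50 nM to 450 nM.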

Compound 4, half-maximal inhibitory concentration: 1100 nM
Compound 4: the middle estimate sits 7.3-fold (0.87 log units) below what was measured; the whole stated range lies below it.
By their numbers in this assay, from the lowest: compound 3; then compounds 4, 1 and 2 (each within the scatter of the next, the first and the last beyond it).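

In this assay, among these compounds, the change from 1-(carboxymethyl)ethyl to 2-carboxyethyl gives the first single-place comparison: a 13-fold higher number from compound 3 to compound 4 (1.11 log units; beyond the scatter). This saturated chain carbon is therefore a sensitive position, since the loss of one methyl alone, with the rest of the structure held fixed, gives a large step. No evidence at hand bears on the reason for this step. Going by these compounds, whether an ethyl group or a longer chain on this carbon would match the methyl remains open. Also open, on these data alone, is whether the methyl gives a step of this size with the amide groups of compound 1 and compound 2.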